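This account rests on a few compounds, and the source may have more. Where it says the series, first, only, none or still open, it means among the compounds named here.

In a functional assay on SNU-423 cells (Homo sapiens) for inhibition, read by MTT assay, with a stated time of 72 h (a lower number here means a stronger inhibitor, a higher number a weaker inhibitor), compound 2 (`Nc1nc2cc(-c3nn(CCCCC(=O)NO)c4ncnc(N)c34)ccc2o1`) gives 3030 nM, the lower of the two measured numbers and beyond the scatter from compound 1 (`Nc1ncnc2c1c(-c1cnc3[nH]ccc3c1)nn2CCCCCCCCCC(=O)NO`), which gives 8160 nM. Compound 3 (`Nc1nc2cc(-c3nn(CCCCCCC(=O)NO)c4ncnc(N)c34)ccc2o1`) extends the chain of compound 2: 2-(hydroxycarbamoyl)ethyl in place of hydroxycarbamoyl on a saturated chain carbon, four bonds along the chain from an aromatic nitrogen, with 2-(hydroxycarbamoyl)ethyl in place of hydroxycarbamoyl on a saturated chain carbon. Among the compounds with values here, no measured pair isolates chain length: compound 1 also differs elsewhere. A modest shift toward stronger inhibition is therefore only a tentative expectation, with an expected size of a 2.0-fold lower number from compound 2 to compound 3 (0.31 log units; beyond the scatter). The estimated value for compound 3 is 1500 nM, within an expected range of 450 nM to 5000 nM.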

Compound 3, half-maximal inhibitory concentration: 6100 nM
The estimate for compound 3 lay 4.1-fold (0.61 log units) below the measured number; measured number outside the range, above it.
By their numbers in this assay, from the lowest: compounds 2, 3 and 1 (each within the scatter of the next, the first and the last beyond it).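

Within the data shown here, with the core held constant, a 2.0-fold higher number from compound 2 to compound 3 (0.30 log units; within the scatter) is the first read of chain length alone in this assay. Compound 1 could not give this read, as it also differs elsewhere. Placing 2-(hydroxycarbamoyl)ethyl in place of hydroxycarbamoyl at this saturated chain carbon therefore does not separate compound 2 from compound 3, and the pair shows no stronger inhibition with the longer chain. Nothing available explains this result. The compounds shown leave open how (hydroxycarbamoyl)methyl in place of hydroxycarbamoyl, or a longer chain, would read. They also leave open whether a carboxylic acid could replace hydroxycarbamoyl at this position.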